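Amine change on the pyridylethyl compounds

This account rests on a few compounds, and the source may have more. Where it says the series, first, only, none or still open, it means among the compounds named here.

Values in a functional assay on L02 cells (Homo sapiens) for inhibition, read by Griess assay, with stated times of 1 h and 24 h; a lower number here means a stronger inhibitor, a higher number a weaker inhibitor:
- compound 1 `CCCc1nn(C)c2c(NCc3ccc(F)cc3)nc(/C=C/c3nc(C)c(C)nc3C)nc12`: > 1000000 nM
- compound 2 `CCCc1nn(C)c2c(NC3CC3)nc(CCc3cccnc3)nc12`: 564000 nM
- compound 3 `CCCc1nn(C)c2c(NC(C)C)nc(CCc3cccnc3)nc12`: 514000 nM

Going by the values given here, compound 3 has a single numeric neighbour in this assay, and the only measured step at this nitrogen, a 1.1-fold lower number from compound 2 to compound 3 (0.04 log units; within the scatter), stays small. That step exchanged cyclopropyl and isopropyl only. The change to compound 4 `CCCc1nn(C)c2c(NCc3ccc(F)cc3)nc(CCc3cccnc3)nc12` is larger: 4-fluorobenzyl in place of isopropyl on a nitrogen on an aromatic ring. Compound 1, which also has the (4-fluorobenzyl)amino group on a different side chain, gives > 1000000 nM, which is a limit. A modest move towards a weaker number is therefore expected, with the step estimated as a 1.3-fold higher number from compound 3 to compound 4 (0.10 log units; within the scatter). The expected value for compound 4 is 650000 nM, with an estimated range of 250000 nM to 1000000 nM.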

Compound 4, half-maximal inhibitory concentration: < 40000 nM
Compound 4: only a limit was reported (the forecaster's own chance of this, stated with the estimate: 30%); middle value at least 16-fold (1.21 log units) away from the limit.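

At the nitrogen, the amine choice now matters: 4-fluorobenzyl gives an at least 12-fold lower number from compound 3 to compound 4 (1.10 log units; beyond the scatter) and an at least 14-fold lower number from compound 2 to compound 4 (1.14 log units; beyond the scatter), whereas cyclopropyl and isopropyl were not separated in this assay. With the (4-fluorobenzyl)amino group held constant, the group on the aromatic carbon also matters: 2-(pyridin-3-yl)ethyl in place of 2-(3,5,6-trimethylpyrazin-2-yl)ethenyl gives an at least 25-fold lower number from compound 1 to compound 4 (1.39 log units; beyond the scatter), a step between two limits. Compound 4 is known only as a limit: the limit of < 40000 nM in this assay, at which 1 of the 4 values shown sits.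

Going by these compounds, the exact size of these steps stays open. Also open, on these data alone, is whether the change depends on the fluorine or the aromatic ring; plain benzyl or cyclohexylmethyl on this nitrogen would separate the two.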